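A few compounds are considered here, and "the series" means these few. Any claim that something is new, unique, unknown or untested is made for them only; others in the source may bear on it.

Measured compounds:
Compound 1 `C/C(=C\CC/C(C)=C/CC[C@@H]1[C@@]2(C)CCC(=O)C(C)(C)[C@H]2CC[C@@]1(C)O)CC/C=C(\C)C(=O)OCc1cn(-c2ccc(Br)cc2)nn1`: in an ADME assay on L132 cells (Homo sapiens) for cytotoxicity, read by MTT assay, with a stated time of 48 h (a lower number here means a stronger inhibitor, a higher number a weaker inhibitor), compound 1 gives > 150000 nM, a limit of the assay rather than a number.
Compound 2 `C/C(=C\CC/C(C)=C/CC[C@@H]1[C@@]2(C)CCC(=O)C(C)(C)[C@H]2CC[C@@]1(C)O)CC/C=C(\C)C(=O)OCc1cn(C[C@@H]2O[C@H](n3ccc(=O)[nH]c3=O)C[C@H]2O)nn1`: in this assay compound 2 gives 148000 nM.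
Compound 3 `C/C(=C\CC/C(C)=C/CC[C@@H]1[C@@]2(C)CCC(=O)C(C)(C)[C@H]2CC[C@@]1(C)O)CC/C=C(\C)C(=O)OCc1cn([C@@H]2C[C@@H](n3cc(C)c(=O)[nH]c3=O)O[C@H]2CO)nn1`: in this assay compound 3 gives 115000 nM.

Compound 1 therefore stands at a limit only: the limit of > 150000 nM in this assay, at which 1 of the 3 values shown sits. Nothing more precise is known of it in this assay. The two compounds with numbers, compound 2 and compound 3, sit within the usual scatter of each other, and both lie close to the limit that compound 1 reaches, so the three members of this shared core all appear as weak inhibitors in this assay.

Compound 4 `COc1ccccc1-n1cc(COC(=O)/C(C)=C/CC/C(C)=C/CC/C(C)=C/CC[C@@H]2[C@@]3(C)CCC(=O)C(C)(C)[C@H]3CC[C@@]2(C)O)nn1` is the untested member. Compared with compound 1 its change is 2-methoxyphenyl in place of 4-bromophenyl on an aromatic nitrogen. For the measured compounds named here, no pair of measured compounds shows what such a change on the aromatic nitrogen does in this assay, so there is no measured step to lean on. Given that all three measured compounds cluster at or near the limit, the step from compound 1 to compound 4 is expected to be a number no higher from compound 1 to compound 4 (the limit leaves the size open), that is, nothing beyond the scatter in either direction. Compound 4 is accordingly estimated at 150000 nM in this assay, within a range from 80000 nM to 300000 nM, with a fair chance that only a limit is reported again.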

Compound 4, half-maximal inhibitory concentration: > 150000 nM
Compound 4 ended at the assay's limit; the forecaster's own chance of this, stated with the estimate: 50%; the middle value sits exactly at the limit.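

Compound 4, like compound 1, ends at a limit of the assay and not at a number: the limit of > 150000 nM in this assay, at which 2 of the 4 values shown sit. For the compounds shown here, no step from compound 1 to compound 4 can be read, so the effect of 2-methoxyphenyl in place of 4-bromophenyl stays unknown. The compounds shown leave open what any change on the aromatic nitrogen does in this assay.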